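Swapping the sulfonyl aryl group of compound 1

This account rests on a few compounds, and the source may have more. Where it says the series, first, only, none or still open, it means among the compounds named here.

Of the compounds shown here, three of one shared core have been measured so far. Compound 1 `Cn1c(=O)c(S(=O)(=O)c2ccc(C(=O)O)cc2)cc2cnc(Nc3ccc4[nH]ccc4c3)nc21` carries a 4-carboxyphenyl on its sulfonyl sulfur and a methyl on the aromatic nitrogen; in a functional assay on DU-145 cells (Homo sapiens) for inhibition, read by trypan blue exclusion, with a stated time of 72 h (a lower number here means a stronger inhibitor, a higher number a weaker inhibitor), compound 1 gives 10000 nM. Compound 2 `O=c1c(S(=O)(=O)c2ccc(F)cc2F)cc2cnc(Nc3ccc4[nH]ccc4c3)nc2n1C1CCCC1` gives 5000 nM, and compound 3 `CCn1c(=O)c(S(=O)(=O)c2ccc(F)cc2F)cc2cnc(Nc3ccc4[nH]ccc4c3)nc21` gives 750 nM. Compound 1 thus has the highest number of the three, within the scatter of compound 2 and well above compound 3. Within the data shown here, the only single-point step available, a 6.7-fold lower number from compound 2 to compound 3 (0.82 log units; beyond the scatter), concerns the group on the aromatic nitrogen and not the sulfonyl aryl.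

Compound 4 `Cn1c(=O)c(S(=O)(=O)c2ccc([N+](=O)[O-])cc2F)cc2cnc(Nc3ccc4[nH]ccc4c3)nc21` differs from compound 1 at the sulfonyl sulfur: 2-fluoro-4-nitrophenyl in place of 4-carboxyphenyl on a sulfonyl sulfur. Among the measured compounds shown here, no measured step changes this group alone, so that one step gives no direct guide. For the measured compounds named here, what the numbers do show is that compound 1, the only member with a carboxylic acid, gives 10000 nM, while compounds carrying a fluorinated phenyl on the same sulfur sit at 5000 nM for compound 2 and 750 nM for compound 3. On that basis compound 4 is expected to move toward a lower number, by an estimated 5.0-fold lower number from compound 1 to compound 4 (0.70 log units; beyond the scatter). Compound 4 is therefore estimated at 2000 nM, with a likely range from 400 nM to 9000 nM.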

Compound 4, half-maximal inhibitory concentration: 400 nM
Compound 4: middle estimate off by 5.0-fold (0.70 log units), on the high side; the range from low to high includes it.
By their numbers in this assay, from the lowest: compounds 4 and 3 (each within the scatter of the next); then compounds 2 and 1 (each within the scatter of the next).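

Among these compounds, compound 4 gives the first direct reading at the sulfonyl sulfur in this assay: with the methyl on the aromatic nitrogen and the rest of the shared core unchanged, 2-fluoro-4-nitrophenyl in place of 4-carboxyphenyl gives a 25-fold lower number from compound 1 to compound 4 (1.40 log units; beyond the scatter). Among the compounds shown here, this step is large, whereas the only earlier step, at the aromatic nitrogen, a 6.7-fold lower number from compound 2 to compound 3 (0.82 log units; beyond the scatter), is modest, so the group on this sulfur emerges as a point at which the number can change strongly. Nothing measured here explains this change, and the step alone cannot say why the number falls.

The step also changes several things at once, as the carboxylic acid leaves while a fluorine and a nitro group enter, so the compounds shown do not divide it among these groups; a 4-nitrophenyl or a 2-fluorophenyl on the same sulfur, with the methyl kept, would separate them. On these data alone, it also remains open how a 4-aminophenyl or the methyl ester of the carboxylic acid would read at this position.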